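One Aryl Change on the Shared Core: Compound 3 Expected

The source may report more compounds than this note shows. Statements on the series, on what has been measured and on what is new or still open speak of the compounds shown alone.

Measured compounds:
compound 1 `COc1ccc(-n2nc(-c3ccc(C(F)(F)F)cc3O)nc2-c2ccccc2O)cc1`: 69%
compound 2 `Oc1cc(C(F)(F)F)ccc1-c1nc(-c2ccccc2O)n(-c2ccccc2C(F)(F)F)n1`: 71%

In a functional assay on PC-12 cells (Rattus norvegicus) for cytotoxicity, read by MTT assay, with stated times of 2 h and 24 h, tested at 1 uM (on this read-out lower numbers stand for a weaker effect and higher numbers for a stronger effect at the one concentration tested), compound 2 gives 71% and compound 1 gives 69%. Compound 2 is not separated from compound 1 on these numbers, since the step of a number 2 percentage points higher from compound 1 to compound 2 (within the scatter) lies within the scatter; the two measured compounds stand together. Compound 3 `Oc1cc(C(F)(F)F)ccc1-c1nc(-c2ccccc2O)n(-c2cccc(Cl)c2)n1` differs from compound 2 in one place: 3-chlorophenyl in place of 2-(trifluoromethyl)phenyl on an aromatic nitrogen. Among the compounds with values here, only one measured step bears on this change, the step from compound 1 to compound 2, which also exchanged the group on that aromatic nitrogen and was a number 2 percentage points higher from compound 1 to compound 2 (within the scatter). Nothing in the data points to a different outcome for a further exchange at the same place, so the step is expected to stay within the scatter, a number 1 percentage points lower from compound 2 to compound 3 (within the scatter). Compound 3 is therefore estimated at 70% in this assay, with a range from 58% to 82%.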

Compound 3, a percentage reported as activity, at one concentration (the size of the read-out at that concentration, not a potency): 72.3%
For compound 3 the middle estimate is 2.3 percentage points below the measured one; low and high end bracket the measured number.
By their numbers in this assay, from the lowest: compounds 1, 2 and 3 (each within the scatter of the next).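

Compound 3 brings a third aryl group onto the same aromatic nitrogen, and in this assay the exchange of 2-(trifluoromethyl)phenyl for 3-chlorophenyl gives a number 1.3 percentage points higher from compound 2 to compound 3 (within the scatter) and the exchange of 4-methoxyphenyl for 3-chlorophenyl gives a number 3.3 percentage points higher from compound 1 to compound 3 (within the scatter). The position therefore tolerates a chlorine-bearing ring with fewer heavy atoms, and all three aryl groups stand together on this read-out, so neither the substituent nor its place on the ring separates these compounds. No measurement shown accounts for this absence of separation.

From the compounds shown here alone, it remains open whether a different kind of group on that nitrogen, such as an aminophenyl ring, a carboxylic acid or a longer alkyl chain, would move the number beyond the scatter. Going by these compounds, the effect of changing the two hydroxyl groups on the shared core also remains open.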